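The source may report more compounds than this note shows. Statements on the series, on what has been measured and on what is new or still open speak of the compounds shown alone.

Measured so far in a physicochemical assay for lipophilicity, read by HPLC; on this read-out lower numbers stand for lower lipophilicity and higher numbers for higher lipophilicity:
- Compound 1 `COc1ccc(NC[C@@H](O)COc2ccc(N3C[C@H](CNC(C)=O)OC3=O)cc2F)cc1` reads 1.15
- Compound 2 `CC(=O)NC[C@H]1CN(c2ccc(OC[C@H](O)CNc3cccnc3)c(F)c2)C(=O)O1` reads -0.18

Of these two compounds, compound 2 stands lower, at -0.18 on this scale, while compound 1 reads 1.15 on the same scale. The next compound, compound 3 `CC(=O)NC[C@H]1CN(c2ccc(OC[C@H](O)CNc3ccncc3)c(F)c2)C(=O)O1`, differs from compound 2 in one place, pyridin-4-yl in place of pyridin-3-yl on an amine nitrogen with pyridin-4-yl in place of pyridin-3-yl on an amine nitrogen. The two have the same atoms, joined differently.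

For the measured compounds named here, one measured step bears on this change, a number 1.33 log units lower from compound 1 to compound 2 (beyond the scatter) and it is large. However, that step exchanged 4-methoxyphenyl for pyridin-3-yl, whereas here one pyridinyl group replaces another. Going by the values given here, no measured pair shows this exchange directly, so the large size is not expected to carry over. A much smaller change is expected, with a tentative lean towards lower numbers that the data do not establish. The expected step is a number 0.22 log units lower from compound 2 to compound 3 (within the scatter) and this remains an uncertain estimate. Compound 3 is estimated at -0.4 in this assay with an expected range from -1 to 0.2 around that figure.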

Compound 3, partition coefficient: 0.02
Compound 3: the middle estimate sits 0.42 log units below what was measured; the measured number falls inside the stated range.
By their numbers in this assay, from the lowest: compounds 2 and 3 (each within the scatter of the next); then compound 1.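

In this assay, pyridin-4-yl in place of pyridin-3-yl on the amine nitrogen gives a number 0.20 log units higher from compound 2 to compound 3 (within the scatter) and so the two pyridinyl isomers cannot be told apart at this position on this read-out. The large step away from 4-methoxyphenyl is therefore not confined to pyridin-3-yl, since pyridin-4-yl in place of 4-methoxyphenyl gives a number 1.13 log units lower from compound 1 to compound 3 (beyond the scatter) and this places both pyridinyl compounds well apart from compound 1. Nothing available here explains these readings or the closeness of the two isomers.

Going by these compounds, it remains open whether pyridin-2-yl on the same amine nitrogen would read with compound 2 and compound 3 or whether moving the ring nitrogen that far would separate it from them. An unsubstituted phenyl group at this position would also help to show how much of the large step belongs to the loss of the methoxy group and how much to the ring nitrogen.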